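Replacing dichlorophenyl with dimethoxyphenyl on the benzylamine arm

The compounds below may be only part of what the source reports. "The series", "measured", "known", "first", "only" and "open" are said of these compounds alone.

Going by the values given here, compound 2 `O=S(=O)(NCCCNCc1ccc(Cl)c(Cl)c1)c1cc(C(F)(F)F)cc(C(F)(F)F)c1` is one of two compounds measured in a functional assay on HT-29 cells (Homo sapiens) for inhibition, read by MTT assay, with a stated time of 72 h; a higher number here means a weaker inhibitor of growth, a lower number a stronger inhibitor of growth. In this assay compound 2 gives 4700 nM, the higher of the two numbers. Among the compounds with values here, its nearest neighbour, compound 1 `CC(C)(C)c1ccc(CNCCCNS(=O)(=O)c2cc(C(F)(F)F)cc(C(F)(F)F)c2)cc1`, gives 2000 nM in this assay, and the two differ in one place, giving the only measured step in the set: a 2.4-fold higher number from compound 1 to compound 2 (0.37 log units; beyond the scatter).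

Compound 3 `COc1ccc(CNCCCNS(=O)(=O)c2cc(C(F)(F)F)cc(C(F)(F)F)c2)cc1OC` has not yet been measured. It differs from compound 2 in one place: 3,4-dimethoxyphenyl in place of 3,4-dichlorophenyl on a saturated chain carbon bound to an amine nitrogen. Within the data shown here, the single measured step swapped a 4-(tert-butyl)phenyl for the 3,4-dichlorophenyl at the same place and moved the number only modestly, and neither measured compound carries a 3,4-dimethoxyphenyl, so no measured step speaks directly to this change. The size of the measured step suggests that changes at this place produce modest movement in this assay, but its direction for compound 3 cannot be read from the data.

Compound 3 is therefore expected to give about 6000 nM, with a range from 2000 nM to 18000 nM. This estimate implies a 1.3-fold higher number from compound 2 to compound 3 (0.11 log units; within the scatter), a step expected to be modest at most.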

Compound 3, concentration for 50% growth inhibition: 2700 nM
For compound 3 the middle estimate is 2.2-fold (0.35 log units) above the measured one, and the stated range covers the measured number.
By their numbers in this assay, from the lowest: compounds 1, 3 and 2 (each within the scatter of the next, the first and the last beyond it).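

In this assay the 3,4-dimethoxyphenyl group gives a 1.7-fold lower number from compound 2 to compound 3 (0.24 log units; within the scatter) and, set against the other arm, a 1.4-fold higher number from compound 1 to compound 3 (0.13 log units; within the scatter). The position on a saturated chain carbon bound to an amine nitrogen has therefore now taken three different aryl groups, and compound 3 cannot be told apart from either compound 1 or compound 2, even though those two stand apart from each other beyond the scatter. Going by these compounds alone, exchanging the two chlorines for two methoxy groups, which by count brings in 2 hydrogen-bond acceptors, thus produces no readable change in growth inhibition here, so the one step beyond the scatter remains the one from compound 1 to compound 2.

No evidence is available on why these three compounds give the numbers they do. On these data alone, it remains open whether a group of another kind on the aromatic ring of this arm, such as an amine or a carboxylic acid, or a longer chain in place of the present one, would shift the number beyond the scatter.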